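The compounds below may be only part of what the source reports. "The series", "measured", "known", "first", "only" and "open" are said of these compounds alone.

Of the compounds shown here, three of this small series have been measured in a functional assay on HepG2 cells (Homo sapiens) for antiproliferative activity, read by sulforhodamine B assay, with a stated time of 48 h; on this read-out higher numbers stand for weaker inhibition and lower numbers for stronger inhibition. Compound 1 `COc1ccc(/C=C/C(=O)c2ccccc2-c2ccc(F)nc2)cc1` gives 290 nM. Compound 2 `COc1ccc(/C=C/C(=O)c2ccccc2-c2ccc(F)nc2)cc1OC` gives 1000 nM. The change between them is methoxy in place of hydrogen on an aromatic carbon and it made the step of a 3.4-fold higher number from compound 1 to compound 2 (0.54 log units; beyond the scatter). Compound 3 `O=C(/C=C/c1ccccc1-c1ccc(F)cc1)c1cccc(O)c1` is built on a different core; how its core differs from that of compound 1 is not broken down here. In this assay compound 3 gives 4200 nM, the highest number of the three, set apart from compound 2 and further still from compound 1, both gaps beyond the scatter.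

Compound 4 `COc1ccc(C(=O)/C=C/c2ccccc2-c2ccc(F)cc2)cc1O` has not yet been measured. It differs from compound 3 by methoxy in place of hydrogen on an aromatic carbon. Within the data shown here, this is the same kind of change as the one from compound 1 to compound 2, but not the same: in compound 2 the entering methoxy sits ortho to a methoxy group and meta to a large group, whereas in compound 4 it sits ortho to a hydroxy group and para to a large group. For compound 4 the expected step is a 1.7-fold higher number from compound 3 to compound 4 (0.22 log units; within the scatter), an estimate resting on the modest rise seen in a 3.4-fold higher number from compound 1 to compound 2 (0.54 log units; beyond the scatter). Among the measured compounds shown here, the range is set wide: the surroundings of the change and the core both differ from that measured pair, and no measured step covers this exact change. Compound 4 is therefore expected to give about 7000 nM, most likely between 2500 nM and 20000 nM.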

Compound 4, half-maximal inhibitory concentration: 190 nM
Beside the measured number, compound 4's estimate is 37-fold (1.57 log units) above it; the whole stated range lies above it.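

In this assay, methoxy in place of hydrogen on an aromatic carbon gave a 22-fold lower number from compound 3 to compound 4 (1.34 log units; beyond the scatter), a large gain in inhibition, whereas the same kind of change on the core of compound 1 gave a 3.4-fold higher number from compound 1 to compound 2 (0.54 log units; beyond the scatter), a modest loss. Set side by side, the two steps run in opposite directions and do not agree within the scatter: the same change on two cores in this assay, a 3.4-fold higher number (0.54 log units; beyond the scatter) from compound 1 to compound 2 and a 22-fold lower number (1.34 log units; beyond the scatter) from compound 3 to compound 4, 76-fold (1.88 log units) apart, beyond the scatter of two such steps This shows that, among the compounds shown, the effect of this change measured on one core cannot be carried over to the other, but it does not show what separates the two results, as the core and the surroundings of the entering methoxy both differ between the pairs.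

The compounds shown leave open whether the gain in compound 4 depends on the hydroxy group ortho to the methoxy, a question that a compound with an amine or a fluorine in place of that hydroxy group could address. They also leave open whether an ethoxy group or a longer alkoxy chain in the position para to a large group would follow the methoxy step, and how the same change would behave on any further core.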